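The source may hold more compounds than are shown below. What is called first, only, known or untested is meant among the compounds shown, and "the series" means these compounds.

Compound 1 `CN(C)CC(=O)N1CCC(NS(=O)(=O)c2cc(S(=O)(=O)c3ccccc3)ccc2C(F)(F)F)CC1` is the starting point. Going by the values given here, in a functional assay on U2OS cells for antagonist activity at proto-oncogene Wnt-3 (Homo sapiens), read by a luciferase reporter, with a stated time of 18 h (on this read-out higher numbers stand for an effect only at larger amounts of compound and lower numbers for an effect already at smaller amounts), compound 1 gives 280 nM, the highest of the three numbers measured so far. Two close relatives replace its (dimethylamino)methyl group with a 1-(tert-butoxycarbonyl)pyrrolidin-2-yl group on the carbonyl carbon. Compound 2 `CC(C)(C)OC(=O)N1CCC[C@H]1C(=O)N1CCC(NS(=O)(=O)c2cc(S(=O)(=O)c3ccccc3)ccc2C(F)(F)F)CC1` gives 60 nM in this assay, a step of a 4.7-fold lower number from compound 1 to compound 2 (0.67 log units; beyond the scatter). Compound 3 `CC(C)(C)OC(=O)N1CCC[C@@H]1C(=O)N1CCC(NS(=O)(=O)c2cc(S(=O)(=O)c3ccccc3)ccc2C(F)(F)F)CC1` gives 210 nM in this assay, a step of a 1.3-fold lower number from compound 1 to compound 3 (0.12 log units; within the scatter). Between these two there is a 3.5-fold higher number from compound 2 to compound 3 (0.54 log units; beyond the scatter), which rests on (the fact that compounds 2 and 3 differ only in the configuration as drawn).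

Compound 4 `CC(C)(C)NC(=O)N1CCC[C@H]1C(=O)N1CCC(NS(=O)(=O)c2cc(S(=O)(=O)c3ccccc3)ccc2C(F)(F)F)CC1` carries the change (1-((tert-butyl)carbamoyl)pyrrolidin-2-yl in place of (dimethylamino)methyl on a carbonyl carbon). Its stereocentre is drawn as in compound 2, so the step from compound 1 to compound 2, a 4.7-fold lower number from compound 1 to compound 2 (0.67 log units; beyond the scatter), is the closest guide, while compound 3 shows that the other drawing loses most of that gain. In this assay compound 4 is expected to show a step of a 3.5-fold lower number from compound 1 to compound 4 (0.54 log units; beyond the scatter). For compound 4 the estimate is 80 nM, with a range from 30 nM to 250 nM.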

Compound 4, half-maximal effective concentration: 30 nM
For compound 4 the middle estimate is 2.7-fold (0.43 log units) above the measured one; the measured number falls inside the stated range.
By their numbers in this assay, from the lowest: compounds 4 and 2 (each within the scatter of the next); then compounds 3 and 1 (each within the scatter of the next).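

Compound 4 shows that the gain over the (dimethylamino)methyl group is not tied to the tert-butoxy carbonyl of compound 2, since 1-((tert-butyl)carbamoyl)pyrrolidin-2-yl also lowers the number (a 9.3-fold lower number from compound 1 to compound 4 (0.97 log units; beyond the scatter)). Exchanging tert-butoxy for (tert-butyl)amino gives no change that can be told from the scatter (a 2.0-fold lower number from compound 2 to compound 4 (0.30 log units; within the scatter)), so the two groups cannot be separated in this assay. The step from the other drawing (a 7.0-fold lower number from compound 3 to compound 4 (0.85 log units; beyond the scatter)) changes both the group and the configuration, so it cannot be credited to either alone, and the only direct read on configuration remains one pair: (the fact that compounds 2 and 3 differ only in the configuration as drawn).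

From the compounds shown here alone, it remains open whether compound 4 drawn the other way would lose as much as compound 3 did. A free ring amine or a carboxylic acid at this place would show how much the tert-butyl-capped group contributes.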